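This account rests on a few compounds, and the source may have more. Where it says the series, first, only, none or still open, it means among the compounds named here.

Compound 1 `O=C(/C(=C/c1ccc(Cl)cc1)CCl)c1ccccc1`: in a functional assay on HBL-100 cells (Homo sapiens) for inhibition, read by sulforhodamine B assay, with a stated time of 48 h (a lower number here means a stronger inhibitor of growth, a higher number a weaker inhibitor of growth), compound 1 gives 3200 nM.
Compound 2 `O=C(/C(=C/c1ccc(Cl)cc1Cl)CCl)c1ccccc1`: in this assay compound 2 gives 3100 nM.
Compound 3 `CC(=O)OC/C(=C\c1ccc(Cl)cc1)C(=O)c1ccc(Cl)cc1`: in this assay compound 3 gives 4000 nM.

Compound 2 differs from compound 1 only by chloro in place of hydrogen on an aromatic carbon, and the step of a 1.0-fold lower number from compound 1 to compound 2 (0.01 log units; within the scatter) shows this change left the growth inhibition essentially unchanged. How the core of compound 3 differs from the core of compound 1 is not broken down here. Compound 4 `CC(=O)OC/C(=C\c1ccc(Cl)cc1Cl)C(=O)c1ccc(Cl)cc1` is still unmeasured; it differs from compound 3 by chloro in place of hydrogen on an aromatic carbon, the same change seen between compound 1 and compound 2, at a place described in identical words. Compound 4 is therefore expected to give a step of a 1.1-fold lower number from compound 3 to compound 4 (0.02 log units; within the scatter), an expectation resting on the step of a 1.0-fold lower number from compound 1 to compound 2 (0.01 log units; within the scatter) that left compound 2 within the scatter of compound 1. Compound 4 is estimated at 3800 nM, with a range expected from 2000 nM to 7500 nM.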

Compound 4, concentration for 50% growth inhibition: 3200 nM
Compound 4: middle estimate off by 1.2-fold (0.07 log units), on the high side; low and high end bracket the measured number.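

In this assay the change from 4-chlorophenyl to 2,4-dichlorophenyl gives a 1.3-fold lower number from compound 3 to compound 4 (0.10 log units; within the scatter) and so leaves growth inhibition essentially unchanged on this second core. The step carries over from the core of compound 1 to the core of compound 3 without a measurable difference: the same change on two cores in this assay, a 1.0-fold lower number (0.01 log units; within the scatter) from compound 1 to compound 2 and a 1.3-fold lower number (0.10 log units; within the scatter) from compound 3 to compound 4, 1.2-fold (0.08 log units) apart, within the scatter of two such steps.
This shows only that the added chloro made no difference on these two cores in this one assay; it does not show that the change would behave alike on any other core, or that it could ever shift growth inhibition in this series.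

The compounds shown leave open how a methoxy group, an amine or a carboxylic acid would read at that place on the ring. They also leave open whether a free hydroxyl in place of the acetate would alter the picture.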